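This account rests on a few compounds, and the source may have more. Where it says the series, first, only, none or still open, it means among the compounds named here.

Measured in a functional assay with Homo sapiens as the target; on this read-out higher numbers stand for weaker inhibition and lower numbers for stronger inhibition:
- compound 1 `CC(C)[C@H](NC(=O)COc1cccc2ccccc12)C(=O)N[C@@H](CC(=O)O)C(=O)COc1ccccc1` gives 11200 nM
- compound 2 `CC(C)[C@H](NC(=O)COc1cccc2ccccc12)C(=O)N[C@@H](CC(=O)O)C(=O)COc1ccc2ccccc2c1` gives 15900 nM
- compound 3 `CC(C)[C@H](NC(=O)COc1cccc2ccccc12)C(=O)N[C@@H](CC(=O)O)C(=O)COc1ccccc1C(F)(F)F` gives 17300 nM

Compound 3 lies within the scatter of both other compounds, with a 1.5-fold higher number from compound 1 to compound 3 (0.19 log units; within the scatter) and a 1.1-fold higher number from compound 2 to compound 3 (0.04 log units; within the scatter) as the two steps leading to it. Still unmeasured is compound 4 `CC(C)[C@H](NC(=O)COc1cccc2ccccc12)C(=O)N[C@@H](CC(=O)O)C(=O)COc1cccc(C(F)(F)F)c1`, which differs from compound 3 by one change (3-(trifluoromethyl)phenyl in place of 2-(trifluoromethyl)phenyl on an oxygen on a saturated carbon): 3-(trifluoromethyl)phenyl in place of 2-(trifluoromethyl)phenyl on an oxygen on a saturated carbon.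

Going by the values given here, no measured compound carries the 3-(trifluoromethyl)phenyl group, so the evidence is indirect. The closest steps are the other changes at this place, namely a 1.4-fold higher number from compound 1 to compound 2 (0.15 log units; within the scatter) and a 1.5-fold higher number from compound 1 to compound 3 (0.19 log units; within the scatter) and a 1.1-fold higher number from compound 2 to compound 3 (0.04 log units; within the scatter) as well. All three stayed within the scatter, so no step beyond the scatter is expected in this assay. The expected step is a 1.2-fold lower number from compound 3 to compound 4 (0.06 log units; within the scatter) and it is not expected to exceed the scatter. For compound 4 the estimated value is 15000 nM with an expected range from 7500 nM to 30000 nM in this read-out.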

Compound 4, half-maximal inhibitory concentration: 16600 nM
Beside the measured number, compound 4's estimate is 1.1-fold (0.04 log units) below it, within the range that was stated.
By their numbers in this assay, from the lowest: compounds 1, 2, 4 and 3 (each within the scatter of the next).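

In this assay, 3-(trifluoromethyl)phenyl in place of 2-(trifluoromethyl)phenyl on this oxygen makes no difference beyond the scatter (a 1.0-fold lower number from compound 3 to compound 4 (0.02 log units; within the scatter)), so these two compounds do not distinguish between the two placements of the trifluoromethyl group. The 3-(trifluoromethyl)phenyl group also stays within the scatter of naphthalen-2-yl (a 1.0-fold higher number from compound 2 to compound 4 (0.02 log units; within the scatter)) and of phenyl (a 1.5-fold higher number from compound 1 to compound 4 (0.17 log units; within the scatter)), which leaves all four aryl groups at this position in a single band. No measured evidence is available to explain this lack of response.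

As far as these compounds go, it remains open whether an amine or a carboxylic acid on the phenyl ring would shift the number beyond the scatter. Also open, from the compounds shown here alone, is whether a saturated ring such as cyclohexyl, in place of the aryl group on this oxygen, would do so.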